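Clearance notes: compound 2 to compound 3

The compounds below may be only part of what the source reports. "The series", "measured", "known", "first", "only" and "open" are said of these compounds alone.

Measured in a toxicity assay on microsomes from liver (Homo sapiens) for metabolic stability, read by LC-MS, using NADPH, tested at 1 uM; on this read-out higher numbers stand for fast clearance and lower numbers for slow clearance:
- compound 1 `Cc1nc(-c2nc3ccccc3[nH]2)c(N2CCN(C(=O)Cn3cnc4cccnc43)[C@H](C)C2)s1`: 23 mL.min-1.g-1
- compound 2 `CCOc1ncc(-c2nc(C(F)(F)F)sc2N2CCN(C(=O)Cn3ccc4cccnc43)[C@H](C)C2)cn1`: 316 mL.min-1.g-1

Of the two numbers, compound 2 at 316 mL.min-1.g-1 holds the higher, and compound 1 at 23 mL.min-1.g-1 lies lower by a gap beyond the usual scatter. Compound 3 `CCOc1ncc(-c2nc(C(F)(F)F)sc2N2CCN(C(=O)Cn3nc(C)cc3C)[C@H](C)C2)cn1` follows from compound 2 by one change: a group of 7 heavy atoms (5 carbon, 2 nitrogen; one five-membered aromatic ring with 2 hetero atoms) in place of a group of 9 heavy atoms (7 carbon, 2 nitrogen; one five-membered aromatic ring with 1 hetero atom, one six-membered aromatic ring with 1 hetero atom), on a saturated chain carbon bound to a carbonyl carbon. The new group is 3,5-dimethyl-1H-pyrazol-1-yl, on a saturated chain carbon bound to a carbonyl carbon. Among the compounds with values here, no measured pair isolates a single change, so this assay offers no direct precedent for this one. With compound 2 already at 316 mL.min-1.g-1, a moderate downward move is expected, and the estimated step is a 2.1-fold lower number from compound 2 to compound 3 (0.32 log units; beyond the scatter). The expected value for compound 3 is 150 mL.min-1.g-1, with an estimated range from 50 mL.min-1.g-1 to 400 mL.min-1.g-1.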

Compound 3, intrinsic clearance in microsomes: 184 mL.min-1.g-1
Estimate against measurement, compound 3: 1.2-fold (0.09 log units) below; measured number inside the range.
By their numbers in this assay, from the lowest: compound 1; then compounds 3 and 2 (each within the scatter of the next).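

In this assay, within the data shown here, the exchange on the saturated chain carbon bound to a carbonyl carbon gives a 1.7-fold lower number from compound 2 to compound 3 (0.23 log units; within the scatter), the first comparison that isolates a single place. At this position, a group with one five-membered and one six-membered aromatic ring can therefore give way to 3,5-dimethyl-1H-pyrazol-1-yl, with its single five-membered aromatic ring, without a change in clearance that stands clear of the scatter. Nothing available explains this result.

From the compounds shown here alone, whether an amine or a carboxylic acid at this place would shift clearance beyond the scatter remains open. Also open, going by these compounds, is whether the ethoxy group or the trifluoromethyl group, both shared by compound 2 and compound 3, would offer a larger step when changed on its own.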